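The source may report more compounds than this note shows. Statements on the series, on what has been measured and on what is new or still open speak of the compounds shown alone.

In a functional assay on A549 cells (Homo sapiens) for inhibition, read by sulforhodamine B assay (a higher number here means a weaker inhibitor of growth, a lower number a stronger inhibitor of growth), compound 1 (`Fc1ccc(-c2ccc(-c3ccc(-c4nc5ccccc5[nH]4)cc3)cc2)cc1`) gives 33200 nM, compound 2 (`FC(F)(F)c1ccc(-c2ccc(-c3ccc(-c4nc5ccccc5[nH]4)cc3)cc2)cc1`) gives 36600 nM and compound 3 (`Clc1cccc(-c2ccc(-c3ccc(-c4nc5ccccc5[nH]4)cc3)cc2)c1`) gives 31100 nM. Compound 2 cannot be separated from the other two: the measured steps are a 1.1-fold higher number from compound 1 to compound 2 (0.04 log units; within the scatter), a 1.1-fold lower number from compound 1 to compound 3 (0.03 log units; within the scatter) and a 1.2-fold lower number from compound 2 to compound 3 (0.07 log units; within the scatter), all within the scatter. Compound 4 (`Oc1cccc2[nH]c(-c3ccc(-c4ccc(-c5ccc(C(F)(F)F)cc5)cc4)cc3)nc12`) departs from compound 2 at a different place, by hydroxy in place of hydrogen on an aromatic carbon. This is hydroxy in place of hydrogen on an aromatic carbon, turning 1H-benzimidazol-2-yl into 4-hydroxy-1H-benzimidazol-2-yl. All three measured steps change only the far aryl group, so none of them tests this position, and their small size says little about it. Going by the values given here, with no direct precedent, only a small shift towards a lower number is expected, and a change in either direction remains open. The expected step is a 1.4-fold lower number from compound 2 to compound 4 (0.15 log units; within the scatter). For compound 4 the estimated value is 26000 nM, within an expected range of 8000 nM to 70000 nM.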

Compound 4, concentration for 50% growth inhibition: 3610 nM
For compound 4 the middle estimate is 7.2-fold (0.86 log units) above the measured one, outside the stated range (below it).
By their numbers in this assay, from the lowest: compound 4; then compounds 3, 1 and 2 (each within the scatter of the next).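

In this assay, turning 1H-benzimidazol-2-yl into 4-hydroxy-1H-benzimidazol-2-yl gives a large step (a 10-fold lower number from compound 2 to compound 4 (1.01 log units; beyond the scatter)). The earlier compounds shown here varied only the far aryl group and stayed within the scatter, whereas this single hydroxy on the six-membered aromatic ring of carbon only shows that growth inhibition in these cells does respond to a change at this other place in the molecule. Nothing available explains why the step is so large.

Whether hydroxy itself is needed remains open, since neither a methoxy nor an amine at this place appears among the compounds shown. Also open, going by these compounds, is whether hydroxy would bring a similar step with the 4-fluorophenyl of compound 1 or the 3-chlorophenyl of compound 3.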